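The source may report more compounds than this note shows. Statements on the series, on what has been measured and on what is new or still open speak of the compounds shown alone.

Three compounds have numbers in a functional assay on A549 cells (Homo sapiens) for antiproliferative activity, read by MTT assay, with a stated time of 72 h (a lower number here means a stronger inhibitor, a higher number a weaker inhibitor), all built around a shared core that carries an aryl group on a nitrogen and, further out, a sulfonamide-bearing phenyl ring. Compound 1 `COc1cc2ncnc(Nc3ccc(Br)cc3)c2cc1OCCCCC(=O)Nc1ccc(S(N)(=O)=O)cc1` reaches only the limit of the assay, giving > 40000 nM. Compound 2 `COc1ccccc1Nc1ncnc2cc(OC)c(OCCCCC(=O)Nc3ccc(S(N)(=O)=O)cc3)cc12` gives 24100 nM. Within the data shown here, the single measured step, an at least 1.6-fold lower number from compound 1 to compound 2 (0.22 log units; that floor lies within the scatter), changes only that aryl group. That step rests on the limit reached by compound 1 (the limit of > 40000 nM in this assay, at which 1 of the 3 values shown sits). Compound 3 `NS(=O)(=O)c1ccc(NC(=S)Nc2ccc3ncnc(Nc4cccc(C(F)(F)F)c4)c3c2)cc1`, in which a thiourea replaces the longer amide linker, gives 10100 nM, the lowest number of the two that are proper numbers, with compound 2 standing beyond the scatter from it.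

Compound 4 `Cc1cccc(Nc2ncnc3ccc(NC(=S)Nc4ccc(S(N)(=O)=O)cc4)cc23)c1` differs from compound 3 in one place: methyl in place of trifluoromethyl on an aromatic carbon. Among the measured compounds shown here, no measured step swaps one substituent on that aryl ring for another; the one step that touches the aryl group, from compound 1 to compound 2, is small and rests on a limit, so it only suggests that changes here are modest. The step from compound 3 to compound 4 in this assay is therefore expected to be small, most likely a slightly higher number, with a 1.5-fold higher number from compound 3 to compound 4 (0.17 log units; within the scatter). Compound 4 is estimated at 15000 nM, within a range of 5000 nM to 40000 nM.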

Compound 4, half-maximal inhibitory concentration: > 40000 nM
Compound 4 was reported as a limit (the forecaster's own chance of this, stated with the estimate: 15%); middle value at least 2.6-fold (0.42 log units) from the limit.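

In this assay, putting methyl in place of trifluoromethyl on an aromatic carbon gives an at least 3.9-fold higher number from compound 3 to compound 4 (0.59 log units; beyond the scatter). The step from compound 1 to compound 2 also changed the aryl group, but its floor lay within the scatter, whereas this floor lies beyond it, so the data now show that a single small group on this aryl ring can matter, at least for the thiourea-linked compounds 3 and 4. Compound 4 stands at a limit of the assay, so the step gives a floor and not a full size: the limit of > 40000 nM in this assay, at which 2 of the 4 values shown sit.

What the exchange of these two groups acts through cannot be told from one pair, and the result does not say whether the trifluoromethyl group is special or the methyl group alone is poorly tolerated at this place. On these data alone, a chlorine atom or a nitrile on the same ring carbon would help separate those readings, and whether the same exchange has a similar effect with the longer amide linker also stays open.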